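This account rests on a few compounds, and the source may have more. Where it says the series, first, only, none or still open, it means among the compounds named here.

Compound 3 `COc1ccccc1NC(=O)Oc1cc(=O)n(CCCO)c2c1CC(C/C=C(\C)CCC=C(C)C)C(C)(C)C2` carries a geranyl-type side chain on its shared core and a carbamate bearing a 2-methoxyphenyl group. In a functional assay on PANC-1 cells (Homo sapiens) for inhibition, read by MTT assay, with a stated time of 24 h, tested at 10 uM (a lower number here means less inhibition, a higher number more inhibition at the concentration tested (going by the name of the read-out)), compound 3 gives 53%, the lowest of the three numbers in hand. Its nearest neighbour is compound 2 `CC(C)=CCC/C(C)=C/CC1Cc2c(OCCCNC(=O)c3ccco3)cc(=O)n(CCCO)c2CC1(C)C`, which in this assay gives 69.5%; the furthest is compound 1 `CC(C)=CCC1Cc2c(OC(=O)Nc3ccc(F)c(Cl)c3)cc(=O)n(CCCO)c2CC1(C)C`, which gives 79.8%. For the measured compounds named here, the one measured step that touches compound 3 runs a number 16.5 percentage points lower from compound 2 to compound 3 (beyond the scatter), where a carbamate took the place of an amide-bearing chain on the ring oxygen.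

Compound 4 `CC(C)=CCC/C(C)=C/CC1Cc2c(OC(=O)Nc3ccc(F)c(Cl)c3)cc(=O)n(CCCO)c2CC1(C)C` differs from compound 3 in one place: 3-chloro-4-fluorophenyl in place of 2-methoxyphenyl on an amide-type nitrogen. Going by the values given here, no measured step makes exactly this swap, so the step cannot be read off directly. What the data do offer is compound 1, which already carries the 3-chloro-4-fluorophenyl carbamate, though on a shorter side chain, and sits far above compound 3 in this assay. On that basis a rise beyond the scatter is expected, with the step from compound 3 to compound 4 estimated at a number 21 percentage points higher from compound 3 to compound 4 (beyond the scatter). Compound 4 is accordingly expected to give about 74% in this assay, with a likely range from 60% to 88%.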

Compound 4, a percentage reported as inhibition, at one concentration (the size of the read-out at that concentration, not a potency): 25%
Beside the measured number, compound 4's estimate is 49 percentage points above it; measured number below the stated range.
By their numbers in this assay, from the lowest: compound 4; then compound 3; then compound 2; then compound 1.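

In this assay the group on the amide-type nitrogen clearly matters, since the number falls a number 28 percentage points lower from compound 3 to compound 4 (beyond the scatter) when 3-chloro-4-fluorophenyl replaces 2-methoxyphenyl. The carbamate group does not set the number alone either: with the 3-chloro-4-fluorophenyl carbamate held fixed, adding 3-methylbut-2-en-1-yl to the side chain brings a fall of a number 54.8 percentage points lower from compound 1 to compound 4 (beyond the scatter) and so makes the side chain a second strong influence. The carbamate on the geranyl-type chain also ends well under the amide-bearing chain, with a drop of a number 44.5 percentage points lower from compound 2 to compound 4 (beyond the scatter) and with (3-chloro-4-fluorophenyl)carbamoyl replacing 3-(((furan-2-yl)carbonyl)amino)propyl on the ring oxygen.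

No supporting measurement is available to explain these falls. The compounds shown leave open how a 2-methoxyphenyl carbamate behaves on the shorter side chain, and how the number would respond to an unsubstituted phenyl ring or a pyridine ring on the amide-type nitrogen.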